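From Ethynyl to 4-Cyanophenyl: An Expected Cytotoxicity Ceiling

This account rests on a few compounds, and the source may have more. Where it says the series, first, only, none or still open, it means among the compounds named here.

Of the compounds shown here, three sharing one core have been tested in an ADME assay on WI-38 cells (Homo sapiens) for cytotoxicity, read by MTT assay, with a stated time of 72 h; a lower number here means a stronger inhibitor, a higher number a weaker inhibitor. Compound 1 `O=C(O)CCc1cccc2c1B(O)OC2` returns a value that is a limit of this assay, > 100000 nM. Compound 2 `C#Cc1cccc(NC(=O)CCc2cccc3c2B(O)OC3)c1` likewise sits at a limit in this assay, > 100000 nM. Compound 3 `COc1ccc(NC(=O)CCc2cccc3c2B(O)OC3)cc1OC` also gives only a limit there, > 100000 nM. Compound 2 therefore stands at the limit of > 100000 nM in this assay, at which 3 of the 3 values shown sit, and no measured step among these three can be set apart from the scatter. Compound 4 `N#Cc1ccc(-c2cccc(NC(=O)CCc3cccc4c3B(O)OC4)c2)cc1` has not yet been measured in this assay; it differs from compound 2 by 4-cyanophenyl in place of ethynyl on an aromatic carbon. Going by the values given here, since every value so far rests on the same limit, the data give no direction for this change, and compound 4 is expected to move no further than the scatter, a number no higher from compound 2 to compound 4 (the limit leaves the size open). Compound 4 is accordingly estimated at 100000 nM in this assay, with a range from 30000 nM to 300000 nM, and most likely this assay will again report only a limit.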

Compound 4, half-maximal inhibitory concentration: 12000 nM
The estimate for compound 4 lay 8.3-fold (0.92 log units) above the measured number; the whole stated range lies above it.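

In this assay, 4-cyanophenyl in place of ethynyl on an aromatic carbon, meta to a large group, gives an at least 8.3-fold lower number from compound 2 to compound 4 (0.92 log units; beyond the scatter), so a change at this position can bring a measurable number into a series that had shown none. As far as these compounds go, compound 2 gives > 100000 nM, which is a limit of the assay, and the full size of the step therefore stays open. The steps among compound 1, compound 2 and compound 3 still cannot be read: the limit of > 100000 nM in this assay, at which 3 of the 4 values shown sit.

The compounds shown do not separate the contribution of the added aromatic ring from that of its nitrile, which a plain phenyl group at this position would address. They also leave open whether an amine or a carboxylic acid on that ring in place of the nitrile would give a similar number.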